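Swapping a Linked Ring for a Sulfur-Bridged Ring

This account rests on a few compounds, and the source may have more. Where it says the series, first, only, none or still open, it means among the compounds named here.

Of the compounds shown here, three have been measured in a functional assay for inhibition of sodium/hydrogen exchanger (Oryctolagus cuniculus); a lower number here means a stronger inhibitor, a higher number a weaker inhibitor. Compound 1, `Cc1cc(C)c(S(C)(=O)=O)cc1C(=O)N=C(N)N`, gives 11 nM. Compound 2, `Cc1ccc(-c2ccc(C(=O)N=C(N)N)cc2S(C)(=O)=O)cc1`, gives 100 nM. Compound 3, `Cc1cc(-c2ccc(Cl)cc2Cl)c(S(C)(=O)=O)cc1C(=O)N=C(N)N`, gives 42 nM, the second highest of the three numbers: compound 1 gives a lower number, and compound 2 a higher one.

Among the measured compounds shown here, the only single step measured so far is a 3.8-fold higher number from compound 1 to compound 3 (0.58 log units; beyond the scatter), which shows that placing a ring where a methyl group stood raised the number somewhat. Compound 4, `Cc1cc(Sc2ccccc2Cl)c(S(C)(=O)=O)cc1C(=O)N=C(N)N`, is not yet measured. It differs from compound 3 in one place: (2-chlorophenyl)sulfanyl in place of 2,4-dichlorophenyl on an aromatic carbon. For the measured compounds named here, no measured step covers this particular exchange, since both compound 3 and compound 4 carry a ring in this position and only the link to it and the chlorine count change. Going by the values given here, the one measured step therefore offers no firm guide, and no step beyond the scatter is expected.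

Compound 4 is accordingly expected to give about 40 nM, with a likely range from 15 nM to 120 nM. That estimate corresponds to an expected step of a 1.1-fold lower number from compound 3 to compound 4 (0.02 log units; within the scatter).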

Compound 4, half-maximal inhibitory concentration: 14 nM
Compound 4: the middle estimate sits 2.9-fold (0.46 log units) above what was measured; the whole stated range lies above it.
By their numbers in this assay, from the lowest: compounds 1 and 4 (each within the scatter of the next); then compound 3; then compound 2.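

In this assay, the exchange at this position gives a 3.0-fold lower number from compound 3 to compound 4 (0.48 log units; beyond the scatter) and so shows that the number can fall again while a ring stays in place. Set against the methyl group of compound 1, the (2-chlorophenyl)sulfanyl group gives a 1.3-fold higher number from compound 1 to compound 4 (0.10 log units; within the scatter) and so a ring at this position need not raise the number. Compound 3 and compound 4 both carry a ring here. Of the two, only compound 3 stands beyond the scatter from compound 1.

No measurement explains why the two ring groups differ. On these data alone, the exchange changes the sulfur link and the chlorine count together, so their separate shares remain open, as does how an amine or a longer alkyl chain would fare at this position.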